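Ester Amide Replaces the Acid Chain on the Same Core

A few compounds are considered here, and "the series" means these few. Any claim that something is new, unique, unknown or untested is made for them only; others in the source may bear on it.

Compound 1 `CC(C)=CCCC1=CC[C@H](C(=O)NCCC(=O)O)[C@@H](c2ccccc2)C1` is the starting point. In an assay on isolated protein for inhibition of Apoptosis regulator Bcl-2 (Homo sapiens), read by fluorescence polarization, with stated times of 5 min and 10 min (a lower number here means a stronger inhibitor, a higher number a weaker inhibitor), compound 1 gives > 23000 nM, which is a limit of the assay and not a number. Within the data shown here, its mirror image, compound 2 `CC(C)=CCCC1=CC[C@@H](C(=O)NCCC(=O)O)[C@H](c2ccccc2)C1`, is the only other compound measured. In this assay compound 2 gives > 23000 nM, again a limit rather than a number. Among the measured compounds shown here, the two differ only in configuration as drawn, and the step that the two limits leave unreadable from compound 1 to compound 2 is left unreadable by the two limits, so no measured step of readable size exists here.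

Compound 3 `COC(=O)c1ccc(NC(=O)[C@H]2CC=C(CCC=C(C)C)C[C@@H]2c2ccccc2)cc1` keeps the core of compound 1 and carries 4-(methoxycarbonyl)phenyl in place of 2-carboxyethyl on an amide-type nitrogen. For the measured compounds named here, no measured step bears on this change; the only comparison at hand is the step from compound 1 to compound 2, whose size cannot be read. Because of the limit of > 23000 nM in this assay, at which 2 of the 2 values shown sit, the expectation for compound 3 is anchored only at the limit. Compound 3 is therefore expected to give an estimated 20000 nM in this assay, with a range from 4000 nM to 60000 nM. The estimated step of an at least 1.1-fold lower number from compound 1 to compound 3 (0.06 log units; that floor lies within the scatter) is expected to stay within the scatter or to remain unreadable.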

Compound 3, inhibition constant: > 23000 nM
Compound 3: only a limit was reported; the forecaster's own chance of this, stated with the estimate: 60%; middle value at least 1.1-fold (0.06 log units) from the limit.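

In this assay compound 3 gives > 23000 nM, a limit of the assay and not a number. Compound 1 also sits at a limit, and the step to compound 3 cannot be read. The compounds shown leave open whether 4-(methoxycarbonyl)phenyl and 2-carboxyethyl on the amide-type nitrogen differ at all in this assay.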